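From a Four-Membered Ring to an Aminophenyl Group

A few compounds are considered here, and "the series" means these few. Any claim that something is new, unique, unknown or untested is made for them only; others in the source may bear on it.

Compound 2 `FC(F)(F)c1cc(NCC2CNC2)c2cn[nH]c2c1` carries an azetidin-3-yl group on a saturated chain carbon bound to a nitrogen on an aromatic ring of the shared core. In an assay for inhibition of Tryptophan 2,3-dioxygenase (Homo sapiens), with stated times of 10 min and 60 min (a higher number here means a weaker inhibitor, a lower number a stronger inhibitor), compound 2 reaches only a limit, > 100000 nM, so its true potency is not pinned down. Compound 1 `FC(F)(F)c1cc(NC[C@H]2CCCN2)c2cn[nH]c2c1`, with pyrrolidin-2-yl at that carbon, gives 6090 nM in this assay. The step of an at least 16-fold higher number from compound 1 to compound 2 (1.21 log units; beyond the scatter) shows how costly that change of ring was. Compound 3 `O=[N+]([O-])c1ccc(CNc2cc(C(F)(F)F)cc3[nH]ncc23)cc1` also stops at a limit in this assay, > 100000 nM. Thus the limit of > 100000 nM in this assay, at which 2 of the 3 values shown sit, marks where compound 2 sits.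

Compound 4 `Nc1cccc(CNc2cc(C(F)(F)F)cc3[nH]ncc23)c1` differs from compound 2 by 3-aminophenyl in place of azetidin-3-yl on a saturated chain carbon bound to a nitrogen on an aromatic ring. Going by the values given here, no measured step covers an aminophenyl group; the only step touching this carbon, from compound 1 to compound 2, was large and ran toward weaker inhibition. Compound 3, which likewise holds a six-membered aromatic ring at that carbon, remains at the limit, so compound 4 is expected to stay weak as well. Compound 4 is therefore expected to show an at least 1.2-fold lower number from compound 2 to compound 4 (0.09 log units; that floor lies within the scatter), with an estimated value of 80000 nM and a range from 15000 nM to 300000 nM.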

Compound 4, half-maximal inhibitory concentration: 2510 nM
Compound 4: the middle estimate sits 32-fold (1.50 log units) above what was measured, and the stated range ends above it.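

Putting 3-aminophenyl on this carbon gives an at least 39-fold lower number from compound 2 to compound 4 (1.60 log units; beyond the scatter) in this assay and also gives a 2.4-fold lower number from compound 1 to compound 4 (0.38 log units; beyond the scatter) in this assay so an aromatic ring here can do better than either saturated ring. Compound 3, which also holds a six-membered aromatic ring at this carbon, gives only the limit > 100000 nM in this assay so the ring alone does not secure activity, and what it carries matters. The step from the azetidine is a floor and not a full size, since compound 2 stands at a limit: the limit of > 100000 nM in this assay, at which 2 of the 4 values shown sit.

As far as these compounds go, how much of the gain belongs to the amine itself remains open. A plain phenyl ring, or a hydroxyl group in place of the amine, would help separate the part played by the ring from the part played by its substituent.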